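This account rests on a few compounds, and the source may have more. Where it says the series, first, only, none or still open, it means among the compounds named here.

Compound 1 `CCC(=O)c1ccc2c(c1)C(n1ccccc1=O)=CC(C)(C)O2` stands at the top of the three numbers in a functional assay (trachea) with Rattus norvegicus as the target (on this read-out higher numbers stand for higher potency (the scale is a negative logarithm) and lower numbers for lower potency), where compound 1 gives 5.85. Within the data shown here, compound 2 `CC1(C)C=C(n2ccccc2=O)c2cc(OC(=O)Nc3ccccc3)ccc2O1` gives 4.89 in this assay, and compound 3 `CC1(C)C=C(n2ccccc2=O)c2cc(OC(=O)Nc3ccccc3F)ccc2O1` gives 4.22 in this assay; the only single-point step among them, a number 0.67 log units lower from compound 2 to compound 3 (beyond the scatter), concerns a ring substituent not present in compound 4. Compound 4 `CC1(C)C=C(n2ccccc2=O)c2cc(C(=N)S)ccc2O1` differs from compound 1 in the group on the aromatic carbon: a group of 3 heavy atoms (1 carbon, 1 nitrogen, 1 sulfur; no ring) in place of a group of 4 heavy atoms (3 carbon, 1 oxygen; no ring), on an aromatic carbon. Among the measured compounds shown here, no measured step bears directly on this exchange, so the expectation for compound 4 rests on the position alone and on the weaker carbamate-bearing compounds 2 and 3; a modest decrease is expected, a number 0.55 log units lower from compound 1 to compound 4 (beyond the scatter). Compound 4 is thus estimated at 5.3 in this assay, within 4.6 to 6.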

Compound 4, logarithm of the reciprocal of the active concentration, log(1/C): 5.96
Compound 4: middle estimate off by 0.66 log units, on the low side; low and high end bracket the measured number.
By their numbers in this assay, from the lowest: compound 3; then compound 2; then compounds 1 and 4 (each within the scatter of the next).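

In this assay, putting the group of 3 heavy atoms (1 carbon, 1 nitrogen, 1 sulfur) in place of propanoyl gives a number 0.11 log units higher from compound 1 to compound 4 (within the scatter), the first step read at this aromatic carbon itself. The position therefore accepts this exchange, with 2 hydrogen-bond donors entering and 0 leaving, without a change beyond the scatter. Nothing available here accounts for this result. As far as these compounds go, whether an amine, a carboxylic acid or a longer chain on this carbon would fare alike stays open. So does the separate contribution of the entering group's sulfur and nitrogen.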